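This account rests on a few compounds, and the source may have more. Where it says the series, first, only, none or still open, it means among the compounds named here.

Within the data shown here, in an ADME assay on microsomes from liver (Homo sapiens) for metabolic stability, read by LC-MS, using NADPH, tested at 10 uM (a higher number here means that the compound lasts longer, a lower number that the compound disappears faster), compound 1 `CCc1ccc(N(CC2CC2)S(=O)(=O)c2ccc3c(c2)C(=O)CC(C2CCOCC2)O3)cc1` gives 0.372 h and compound 2 `CCc1ccc(N(CC(C)C)S(=O)(=O)c2ccc3c(c2)C(=O)CC(C2CCOCC2)O3)cc1` gives 0.0717 h, so compound 2 holds the lower of the two numbers so far. Compound 3 `CC(C)CN(c1ccc(N(C)C)cc1)S(=O)(=O)c1ccc2c(c1)C(=O)CC(C1CCOCC1)O2` keeps the sulfonamide nitrogen substituent of compound 2 and changes 4-ethylphenyl to 4-(dimethylamino)phenyl: dimethylamino in place of ethyl on an aromatic carbon, para to a large group (dimethylamino in place of ethyl on an aromatic carbon). Among the measured compounds shown here, only one measured step is available, a 5.2-fold lower number from compound 1 to compound 2 (0.72 log units; beyond the scatter), a modest step beyond the scatter, with isopropyl in place of cyclopropyl on a saturated chain carbon bound to a sulfonamide nitrogen. That step shows that the numbers in this assay can shift within this series, but it lies at a different place in the structure. For the measured compounds named here, no measured step covers a change on this aromatic carbon, so neither a size nor a direction can be carried over. The expected result is therefore no step beyond the scatter, and the estimated change is a 1.1-fold lower number from compound 2 to compound 3 (0.04 log units; within the scatter). The half-life expected for compound 3 is 0.065 h, with an estimated range of 0.025 h to 0.17 h.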

Compound 3, half-life: 0.213 h
Compound 3: middle estimate off by 3.3-fold (0.52 log units), on the low side, outside the stated range (above it).
By their numbers in this assay, from the lowest: compound 2; then compounds 3 and 1 (each within the scatter of the next).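

Dimethylamino in place of ethyl on an aromatic carbon, para to a large group, gives a 3.0-fold higher number from compound 2 to compound 3 (0.47 log units; beyond the scatter) in this assay and so moves the half-life beyond the scatter. Among these compounds, the only earlier step (a 5.2-fold lower number from compound 1 to compound 2 (0.72 log units; beyond the scatter)) lay on the sulfonamide nitrogen substituent and ran towards a lower number, so the series now has a second place where the half-life responds, and here the change from 4-ethylphenyl to 4-(dimethylamino)phenyl raises the number. Nothing on hand accounts for this rise, which remains an observation from a single pair of compounds.

As far as these compounds go, it remains open whether the rise depends on dimethylamino itself or would also appear with another group on this aromatic carbon, such as methoxy, a primary amine, morpholine or a longer alkyl chain. Among the compounds shown here, it is equally open whether the same exchange would give a step of similar size and direction on the cyclopropyl side of the series, where compound 1 carries 4-ethylphenyl, since the two changes have not yet been seen together in one compound here.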